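Swapping chloro for methyl on an anilino quinone core

A few compounds are considered here, and "the series" means these few. Any claim that something is new, unique, unknown or untested is made for them only; others in the source may bear on it.

Measured compounds:
- Compound 1, `O=C1C(Nc2ccccc2)=CC(=O)c2ncncc21`: in a functional assay on SK-OV-3 cells (Homo sapiens) for cytotoxicity, read by MTT assay, with a stated time of 72 h (on this read-out higher numbers stand for weaker inhibition and lower numbers for stronger inhibition), compound 1 gives < 0.01 ug/mL, which is a limit of the assay rather than a number.
- Compound 2, `O=C1C(Nc2ccc(Cl)cc2)=CC(=O)c2ncncc21`: in this assay compound 2 gives 0.01 ug/mL.

Going by the values given here, compound 2 stands as the only compound with a plain number in this assay; the single other value is a limit, as the entry the limit of < 0.01 ug/mL in this assay, at which 1 of the 2 values shown sits, shows. Among the compounds with values here, the one measured step, a number no lower from compound 1 to compound 2 (the limit leaves the size open), has no readable size because compound 1 sits at the limit.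

Compound 3, `Cc1ccc(NC2=CC(=O)c3ncncc3C2=O)cc1`, is not yet measured. It differs from compound 2 by methyl in place of chloro on an aromatic carbon. Within the data shown here, only the step from compound 1 to compound 2 touches this part of the structure, and its size is open, so no firm guide exists for the direction of the change. The step of a 2.0-fold higher number from compound 2 to compound 3 (0.30 log units; within the scatter) is therefore expected to stay within the usual scatter. Compound 3 is estimated to give 0.02 ug/mL in this assay, with a range from 0.005 ug/mL to 0.08 ug/mL.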

Compound 3, half-maximal inhibitory concentration: 0.03 ug/mL
Compound 3: the middle estimate sits 1.5-fold (0.18 log units) below what was measured; the range from low to high includes it.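

In this assay, the swap of groups on this aromatic carbon, para to a large group, now gives a step of readable size: a 3.0-fold higher number from compound 2 to compound 3 (0.48 log units; beyond the scatter). Two groups of one heavy atom each can therefore be told apart here, with methyl giving the weaker inhibition of the pair. Methyl in place of hydrogen also weakens inhibition, as the second step shows, an at least 3.0-fold higher number from compound 1 to compound 3 (0.47 log units; beyond the scatter), but that size is only a lower bound because compound 1 sits at a limit of the assay: the limit of < 0.01 ug/mL in this assay, at which 1 of the 3 values shown sits.

The step from hydrogen to chloro still cannot be read, so it stays unclear whether chloro costs any activity compared with hydrogen. Also open, as far as these compounds go, is how an amine, a methoxy group or a longer chain such as ethyl on this same carbon would compare with chloro and methyl.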